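A few compounds are considered here, and "the series" means these few. Any claim that something is new, unique, unknown or untested is made for them only; others in the source may bear on it.

Values in a functional assay on HT-29 cells (Homo sapiens) for cytotoxicity, read by MTT assay, with a stated time of 24 h; a higher number here means a weaker inhibitor, a lower number a stronger inhibitor:
- compound 1 `Cn1c(-c2ccc(NC(=O)CSc3nc4ccccc4s3)cc2)nc(-c2ccccc2)c1-c1ccccc1`: 18 ug/mL
- compound 2 `Cn1cnnc1SCC(=O)Nc1ccc(-c2nc(-c3ccccc3)c(-c3ccccc3)n2C)cc1`: 10.7 ug/mL
- compound 3 `CN(C)/C=C/N1CCN(CC(=O)Nc2ccc(-c3nc(-c4ccccc4)c(-c4ccccc4)n3C)cc2)CC1`: 80 ug/mL

Compound 3 stands at the highest number of the three in this assay; the nearest is compound 1 at a 4.4-fold higher number from compound 1 to compound 3 (0.65 log units; beyond the scatter), the furthest is compound 2 at a 7.5-fold higher number from compound 2 to compound 3 (0.87 log units; beyond the scatter). Between compound 1 and compound 2 the gap is a 1.7-fold lower number from compound 1 to compound 2 (0.23 log units; within the scatter).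

Compound 4 `Cn1c(-c2ccc(NC(=O)CN3CCN(Cc4ccc(Cl)cc4)CC3)cc2)nc(-c2ccccc2)c1-c1ccccc1` keeps the core and the piperazinyl-acetamide chain of compound 3 and differs only in 4-chlorobenzyl in place of 2-(dimethylamino)ethenyl on an amine nitrogen in a ring. For the measured compounds named here, no measured step touches that ring nitrogen: the steps from compound 1 and compound 2 to compound 3 exchange the whole group on the chain carbon, so they show only that this part of the molecule can move the number by a modest amount, not in which direction a change on the piperazine nitrogen goes. The expectation for compound 4 in this assay is therefore loosely held: a step of a 2.0-fold lower number from compound 3 to compound 4 (0.30 log units; within the scatter) is estimated, leaning toward the lower numbers of compound 1 and compound 2, with wide uncertainty. Compound 4 is expected at 40 ug/mL, within 15 ug/mL to 110 ug/mL.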

Compound 4, half-maximal inhibitory concentration: 12 ug/mL
Compound 4: middle estimate off by 3.3-fold (0.52 log units), on the high side, and the stated range ends above it.
By their numbers in this assay, from the lowest: compounds 2, 4 and 1 (each within the scatter of the next); then compound 3.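

In this assay the group on the amine nitrogen of the piperazine ring proves to matter on its own, with 4-chlorobenzyl in place of 2-(dimethylamino)ethenyl giving a 6.7-fold lower number from compound 3 to compound 4 (0.82 log units; beyond the scatter) while the rest of the molecule stays fixed. The high number of compound 3 therefore does not belong to the piperazinyl-acetamide chain as such: compound 4 keeps that chain at 12 ug/mL and lies within the scatter of compound 1 at 18 ug/mL, which carries the (1,3-benzothiazol-2-yl)sulfanyl group instead. No measurement at hand accounts for this step.

Still open, going by these compounds, is which part of the exchange carries the step, the aromatic ring, the chlorine or the departure of the dimethylamino group. An unsubstituted benzyl and a methyl on the same ring nitrogen would begin to separate these, and a longer chain to the aromatic ring would test the spacing.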